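This account rests on a few compounds, and the source may have more. Where it says the series, first, only, none or still open, it means among the compounds named here.

Measured in a functional assay on MCF7 cells (Homo sapiens) for cytotoxicity, read by MTT assay, with a stated time of 72 h; on this read-out lower numbers stand for stronger inhibition and higher numbers for weaker inhibition:
compound 1 `NN1C(=O)/C(=C/c2c[nH]c3ccccc23)SC1=S` gives > 50000 nM, a limit of the assay
compound 2 `O=C1NC(=O)/C(=C/c2c[nH]c3ccccc23)S1` gives > 50000 nM, a limit of the assay
compound 3 `O=C1NC(=S)S/C1=C\c1c[nH]c2ccc(Br)cc12` gives 3650 nM

Compound 2 sits at the limit of > 50000 nM in this assay, at which 2 of the 3 values shown sit; no number is known for it, only that it lies at that limit. Compound 3, which also carries a bromo on the aromatic ring, gives 3650 nM in this assay. Compound 4 `O=C1NC(=O)/C(=C/c2c[nH]c3ccc(Br)cc23)S1` differs from compound 2 by bromo in place of hydrogen on an aromatic carbon. Among the compounds with values here, no measured pair covers this change on its own, so the size of the step rests on compound 3 alone. A step toward stronger inhibition, beyond the scatter, is expected: an at least 3.3-fold lower number from compound 2 to compound 4 (0.52 log units; beyond the scatter). Compound 4 is expected to give 15000 nM in this assay, within a range from 4000 nM to 50000 nM, with a real chance that only a limit is reported.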

Compound 4, half-maximal inhibitory concentration: > 50000 nM
Compound 4 ended at the assay's limit (the forecaster's own chance of this, stated with the estimate: 35%); middle value at least 3.3-fold (0.52 log units) away from the limit.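

Compound 2 and compound 4 both stand at a limit and not at a number, so no step can be read between them: the limit of > 50000 nM in this assay, at which 3 of the 4 values shown sit.
On these data alone, whether bromo in place of hydrogen on an aromatic carbon changes the cytotoxicity of compound 2 at all remains open.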